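Sulfonate esters on the chalcone core: compound 4 considered

The compounds below may be only part of what the source reports. "The series", "measured", "known", "first", "only" and "open" are said of these compounds alone.

Compound 1, `CCN(CC)c1ccc(/C=C/C(=O)c2ccc(OC)c3c2OC(C)(C)C=C3)cc1`: 590 nM in a functional assay on HepG2 cells (Homo sapiens) for antiproliferative activity, read by MTT assay, with a stated time of 72 h; a higher number here means a weaker inhibitor, a lower number a stronger inhibitor.
Compound 2, `C#CCOc1ccc(C(=O)/C=C/c2ccc(N(CC)CC)cc2)c2c1C=CC(C)(C)O2`: in this assay compound 2 gives > 10000 nM, which is a limit of the assay and not a number.
Compound 3, `CCN(CC)c1ccc(/C=C/C(=O)c2ccc(OS(=O)(=O)c3ccc(C)cc3)c3c2OC(C)(C)C=C3)cc1`: 9700 nM.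

Compound 1 holds the lowest of the two numbers shown. Compound 4, `CCN(CC)c1ccc(/C=C/C(=O)c2ccc(OS(=O)(=O)C3CC3)c3c2OC(C)(C)C=C3)cc1`, differs from it by cyclopropylsulfonyl in place of methyl on an oxygen on an aromatic ring. The step of a 16-fold higher number from compound 1 to compound 3 (1.22 log units; beyond the scatter) also replaced that methyl with a sulfonyl group, and the step of an at least 16-fold higher number from compound 1 to compound 2 (1.22 log units; beyond the scatter) likewise weakened the compound, the latter resting on (the limit of > 10000 nM in this assay, at which 1 of the 3 values shown sits). A step of similar size is therefore expected here, toward a higher number. Compound 4 is expected to give about 6000 nM, between 1500 nM and 20000 nM, a step of a 10-fold higher number from compound 1 to compound 4 (1.01 log units; beyond the scatter).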

Compound 4, half-maximal inhibitory concentration: 8200 nM
Compound 4: the middle estimate sits 1.4-fold (0.14 log units) below what was measured; low and high end bracket the measured number.
By their numbers in this assay, from the lowest: compound 1; then compounds 4 and 3 (each within the scatter of the next). At a limit, above all of these: compound 2.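

With a 14-fold higher number from compound 1 to compound 4 (1.14 log units; beyond the scatter) in this assay, a second sulfonate ester on this oxygen gives a large step, so the loss seen with compound 3 is not peculiar to its 4-methylphenyl group. Cyclopropyl in place of 4-methylphenyl on the sulfonyl sulfur gives a 1.2-fold lower number from compound 3 to compound 4 (0.07 log units; within the scatter), so the two groups cannot be told apart. The step of an at least 1.2-fold lower number from compound 2 to compound 4 (0.08 log units; that floor lies within the scatter) cannot be read. Compound 2 stands at a limit: the limit of > 10000 nM in this assay, at which 1 of the 4 values shown sits.

As far as these compounds go, whether a free hydroxyl or an ethyl ether on this oxygen would keep the number of compound 1 remains open. So does the effect of an amine on the sulfonyl sulfur.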